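The source may report more compounds than this note shows. Statements on the series, on what has been measured and on what is new or still open speak of the compounds shown alone.

Compound 1, `CSc1nc(Cl)c2ccn(COCCO)c2n1`, in a functional assay on BSC-1 cells (Cercopithecidae) for cytotoxicity; a higher number here means a weaker inhibitor, a lower number a stronger inhibitor: > 100000 nM
Compound 2, `CSc1nc(N)c2ccn(COCCO)c2n1`: > 100000 nM
Compound 3, `Nc1ncnc2c1ccn2COCCO`: > 100000 nM

Each of these three values is a limit of this assay and not a measured number. Compound 1 gave no readable number below the limit. Compound 2 gave none either. Compound 3 stands at the same limit, so its position among the three cannot be ranked at all; the whole set sits on one line: the limit of > 100000 nM in this assay, at which 3 of the 3 values shown sit.

The two measured changes within this set, a step that the two limits leave unreadable from compound 1 to compound 2 and a step that the two limits leave unreadable from compound 2 to compound 3, both start and end at that limit. Neither size can be read, and neither tells anything about direction.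

Compound 4, `CS(=O)(=O)c1nc(N)c2ccn(COCCO)c2n1`, differs from compound 3 by methylsulfonyl in place of hydrogen on an aromatic carbon. Among the compounds with values here, no measured step touches this particular change, and the two steps that exist offer only the fact that every variation of the shared core tried so far stayed at the limit. The reasonable expectation is therefore that nothing changes beyond the scatter. Compound 4 is expected to show a step that the limit leaves unreadable from compound 3 to compound 4 in this assay. The estimate for compound 4 is 150000 nM, with a range from 50000 nM to 500000 nM, and the result will most probably again be reported only as a limit.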

Compound 4, half-maximal inhibitory concentration: > 100000 nM
Compound 4 ended at the assay's limit (the forecaster's own chance of this, stated with the estimate: 85%); the middle value is on the limit's open side.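

In this assay compound 4 gives > 100000 nM, which is a limit and not a measured number. The steps to compound 4 from compound 2 and compound 3 therefore cannot be read, as all four compounds share one line: the limit of > 100000 nM in this assay, at which 4 of the 4 values shown sit.

The compounds shown leave open whether any variation of the shared core would give a readable number in this assay.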